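The compounds below may be only part of what the source reports. "The series", "measured", "known", "first", "only" and "open" are said of these compounds alone.

Of the compounds shown here, two have so far been tested in a functional assay on T29Kt1 cells (Homo sapiens) for cytotoxicity, read by sulforhodamine B assay, with a stated time of 3 days; a lower number here means a stronger inhibitor, a higher number a weaker inhibitor. Compound 1 (`O=Cc1cn(Cc2ccc(Br)c(Br)c2)c2ccccc12`) gives 630 nM, and compound 2 (`O=Cc1cn(Cc2ccc(Cl)cc2)c2cc(F)ccc12`) gives 9190 nM. Compound 2 has the higher number of the two and is the weaker inhibitor, with a gap to compound 1 that lies beyond the usual scatter of repeat measurements. These two compounds differ in more than one place, and their gap does not isolate any single change. Compound 3 (`O=Cc1cn(Cc2ccc(Cl)cc2)c2cc(Br)ccc12`) matches compound 2 except for one swap: bromo in place of fluoro on an aromatic carbon. Among the measured compounds shown here, no measured pair shows this swap directly. For the measured compounds named here, the only hint is that compound 1, which also carries bromine though elsewhere in the structure, sits at 630 nM. On that slim basis, a modest drop in the number is expected, roughly a 3.1-fold lower number from compound 2 to compound 3 (0.49 log units; beyond the scatter), and it may only just clear the scatter. The estimated value for compound 3 is 3000 nM, with an expected range from 900 nM to 10000 nM.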

Compound 3, half-maximal inhibitory concentration: 32000 nM
Estimate against measurement, compound 3: 11-fold (1.03 log units) below, and the stated range ends below it.
By their numbers in this assay, from the lowest: compound 1; then compound 2; then compound 3.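

In this assay, among the compounds shown here, bromo in place of fluoro on this aromatic carbon of the shared core gives a 3.5-fold higher number from compound 2 to compound 3 (0.54 log units; beyond the scatter), the first direct reading of this position, and it shows the swap weakening inhibition by more than the usual scatter. The position therefore responds to which of these two halogens it carries, and of this pair, fluoro goes with the stronger inhibitor. Nothing available explains why the number rises with this swap.

From the compounds shown here alone, what a different group on this carbon would do remains open, for example a methoxy group, an amine or a plain hydrogen. Going by these compounds, it is also open whether the same swap would move the number in the same direction on another aromatic carbon of the structure.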